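Removing one hydroxy from a dihydroxyphenyl cyclohexanone

This account rests on a few compounds, and the source may have more. Where it says the series, first, only, none or still open, it means among the compounds named here.

Three compounds share one core and differ only in the ring that hangs from one of the two double-bonded chain carbons. In a functional assay on RKO cells (Homo sapiens) for antiproliferative activity, read by MTT assay, with a stated time of 72 h (a lower number here means a stronger inhibitor, a higher number a weaker inhibitor), compound 1 `COc1cc(/C=C2\CCC/C(=C\c3ccc(F)c(F)c3)C2=O)cc(OC)c1OC` gives 2200 nM. Compound 2 `COc1cc(/C=C2\CCC/C(=C\c3ccc(O)c(O)c3)C2=O)cc(OC)c1OC` gives 3100 nM in this assay, and compound 3 `COc1cc(/C=C2\CCC/C(=C\c3ccccc3Br)C2=O)cc(OC)c1OC` gives 2500 nM. Compound 2 has the highest of the three numbers, but the step of a 1.4-fold higher number from compound 1 to compound 2 (0.15 log units; within the scatter) and the step of a 1.2-fold lower number from compound 2 to compound 3 (0.09 log units; within the scatter) are both within the scatter, so the three compounds cannot be told apart on these data.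

Compound 4 `COc1cc(/C=C2\CCC/C(=C\c3cccc(O)c3)C2=O)cc(OC)c1OC` has not yet been measured. Compared with compound 2 the change is hydrogen in place of hydroxy on an aromatic carbon; read one bond further out, a 3,4-dihydroxyphenyl becomes a 3-hydroxyphenyl. Among the compounds with values here, no measured step removes a single hydroxy, so the change is judged only from its neighbours. The step of a 1.4-fold higher number from compound 1 to compound 2 (0.15 log units; within the scatter) swapped two fluorines for two hydroxy groups on that ring without leaving the scatter, and the step of a 1.2-fold lower number from compound 2 to compound 3 (0.09 log units; within the scatter) exchanged the whole substitution pattern for a single bromine, again within the scatter. A smaller change at the same place is therefore expected to give a step of about a 1.1-fold lower number from compound 2 to compound 4 (0.04 log units; within the scatter), that is, none beyond the scatter. Compound 4 is estimated at 2800 nM in this assay, with a range from 1400 nM to 5600 nM.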

Compound 4, half-maximal inhibitory concentration: 6500 nM
For compound 4 the middle estimate is 2.3-fold (0.37 log units) below the measured one, outside the stated range (above it).
By their numbers in this assay, from the lowest: compounds 1, 3 and 2 (each within the scatter of the next); then compound 4.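

In this assay, within the data shown here, this ring position no longer looks indifferent: the loss of one hydroxy gives a 2.1-fold higher number from compound 2 to compound 4 (0.32 log units; beyond the scatter), whereas no step among the earlier compounds left the scatter. Compound 4 also separates from the two other rings, with a 2.6-fold higher number from compound 3 to compound 4 (0.41 log units; beyond the scatter) and a 3.0-fold higher number from compound 1 to compound 4 (0.47 log units; beyond the scatter), which makes it the weakest of the four compounds. The smallest edit shown, hydrogen in place of hydroxy on an aromatic carbon, thus gives a step beyond the scatter, while the larger exchanges of substituents among compound 1, compound 2 and compound 3 do not, so the size of the structural change does not track the size of the step in this set.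

Nothing available here explains why the 3-hydroxyphenyl ring stands apart. The compounds shown also leave open whether a 4-hydroxyphenyl ring would behave like the 3-hydroxyphenyl ring of compound 4, and whether a methoxy group, an amine or a carboxylic acid in place of the remaining hydroxy would move the number in either direction.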